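Bromo replaces the side chain of compound 2

This account rests on a few compounds, and the source may have more. Where it says the series, first, only, none or still open, it means among the compounds named here.

compound 1 `CC(C)CCn1c(Cn2c(=O)n(C(C)C)c3ccccc32)nc2cc(CN(C)C)ccc21`: 5650 nM
compound 2 `CC(C)CCn1c(Cn2c(=O)n(C(C)C)c3ccccc32)nc2cc(CNS(C)(=O)=O)ccc21`: 30800 nM

In an ADME assay on HEp-2 cells (Homo sapiens) for cytotoxicity (a lower number here means that less compound is tolerated, a higher number that more compound is tolerated), compound 2 gives 30800 nM as the higher of the two numbers, and compound 1 stands lower at 5650 nM on the same scale. Still unmeasured is compound 3 `CC(C)CCn1c(Cn2c(=O)n(C(C)C)c3ccccc32)nc2cc(Br)ccc21` with bromo in place of (methanesulfonamido)methyl on an aromatic carbon. Its difference from compound 2 is bromo in place of (methanesulfonamido)methyl on an aromatic carbon in full. Among the measured compounds shown here, the only measured step bearing on this is a 5.5-fold higher number from compound 1 to compound 2 (0.74 log units; beyond the scatter) where methanesulfonamido takes the place of dimethylamino on a saturated chain carbon bound to an aromatic carbon. For the measured compounds named here, compound 3 carries neither group, and no measured compound carries bromo, so that step offers only a rough scale. A smaller step toward a lower number is expected, estimated as a 2.2-fold lower number from compound 2 to compound 3 (0.34 log units; beyond the scatter) in this assay on this thin evidence. Compound 3 is expected at 14000 nM with an estimated range of 5000 nM to 40000 nM.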

Compound 3, half-maximal cytotoxic concentration: 18100 nM
Compound 3: middle estimate off by 1.3-fold (0.11 log units), on the low side; the measured number falls inside the stated range.
By their numbers in this assay, from the lowest: compound 1; then compounds 3 and 2 (each within the scatter of the next).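

In this assay, the step of a 1.7-fold lower number from compound 2 to compound 3 (0.23 log units; within the scatter) shows that the whole (methanesulfonamido)methyl group can give way to a single bromo on this aromatic carbon without leaving the scatter, so the sulfonamide-bearing side chain is not needed for the number compound 2 reaches. The step of a 3.2-fold higher number from compound 1 to compound 3 (0.51 log units; beyond the scatter) shows that compound 1, with its (dimethylamino)methyl group, stands apart from both other compounds, which makes it the lowest of the three by steps beyond the scatter. Nothing at hand explains this difference.

The compounds leave open whether another amine on the saturated chain carbon, such as a primary amine or a pyrrolidine, would fall with compound 1. They also leave open whether a carboxylic acid, a longer chain, or chloro on this aromatic carbon would stay with compound 2 and compound 3.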